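Methoxy addition on aryl piperazine oxazole amides

The source may report more compounds than this note shows. Statements on the series, on what has been measured and on what is new or still open speak of the compounds shown alone.

In a functional assay on HL-60 cells (Homo sapiens) for inhibition, read by MTT assay, with a stated time of 72 h (on this read-out lower numbers stand for stronger inhibition and higher numbers for weaker inhibition), compound 1 `COc1cc(OC)cc(N2CCN(C(=O)c3oc(C)nc3-c3ccc(F)cc3)CC2)c1` gives 38.5 nM, while compound 2 `COc1cccc(N2CCN(C(=O)c3oc(C)nc3-c3ccc(F)cc3)CC2)c1` gives 112 nM. The step of a 2.9-fold lower number from compound 2 to compound 1 (0.46 log units; beyond the scatter) corresponds to the change (methoxy in place of hydrogen on an aromatic carbon). Compound 3 `CCc1nc(-c2ccc(OC)cc2)c(C(=O)N2CCN(c3cccc(Cl)c3)CC2)o1` is recorded only at a limit of this assay, > 1000 nM (the limit of > 1000 nM in this assay, at which 1 of the 3 values shown sits). The difference between the core of compound 2 and that of compound 3 is not broken down here. Compound 4 `CCc1nc(-c2ccc(OC)c(OC)c2)c(C(=O)N2CCN(c3cccc(Cl)c3)CC2)o1` carries the same kind of change, (methoxy in place of hydrogen on an aromatic carbon); the surroundings differ, the entering methoxy standing ortho to a methoxy group in compound 4 but meta to a methoxy group in compound 1. Because compound 3 sits at the limit > 1000 nM, the expected step that the limit leaves unreadable from compound 3 to compound 4 rests mainly on a 2.9-fold lower number from compound 2 to compound 1 (0.46 log units; beyond the scatter), from a different core. For compound 4 in this assay the expected value is 1500 nM, estimated to lie between 400 nM and 6000 nM.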

Compound 4, half-maximal inhibitory concentration: "not active" (no number reported)
No number was reported for compound 4; there is nothing to compare the estimate with.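

Compound 4 is recorded as not active, with no number, so no step from compound 3 to compound 4 can be read, and compound 3 itself stands at a limit: the limit of > 1000 nM in this assay, at which 1 of the 4 values shown sits.

As far as these compounds go, whether 4-methoxyphenyl to 3,4-dimethoxyphenyl shifts inhibition at all on this core stays open.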